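The source may hold more compounds than are shown below. What is called first, only, known or untested is meant among the compounds shown, and "the series" means these compounds.

In an ADME assay on HEK293 cells (Homo sapiens) for inhibition, read by MTT assay, with a stated time of 48 h (on this read-out higher numbers stand for weaker inhibition and lower numbers for stronger inhibition), compound 1 (`CCc1ccc(-c2nc3ccccn3c2Sc2ccccc2)cc1`) gives > 100000 nM, which is a limit of the assay and not a number. Compound 2 (`Cc1ccc(-c2nc3ccccn3c2Sc2ccccc2)cc1`) gives > 100000 nM, again a limit. Compound 3 (`COc1ccc(-c2nc3ccccn3c2Sc2ccccc2)cc1`) gives > 100000 nM, also a limit. Compound 3 therefore has no number of its own and stands with the other two at the limit of > 100000 nM in this assay, at which 3 of the 3 values shown sit.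

Compound 4 (`C(=C/c1nc2ccccn2c1Sc1ccccc1)\c1ccccc1`) carries 2-phenylethenyl in place of 4-methoxyphenyl on an aromatic carbon. The measured steps that come closest are a step that the two limits leave unreadable from compound 1 to compound 3 and a step that the two limits leave unreadable from compound 2 to compound 3, with a step that the two limits leave unreadable from compound 1 to compound 2 alongside them. None of the three has a readable size, and none replaces the whole 4-methoxyphenyl group, so they offer no size or direction to carry over. In this assay, no step beyond the scatter is therefore expected, and the estimated step is a number no higher from compound 3 to compound 4 (the limit leaves the size open). Compound 4 is expected to stay close to the limit, with an estimated value of 100000 nM and a range from 30000 nM to 150000 nM.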

Compound 4, half-maximal inhibitory concentration: > 100000 nM
Compound 4: only a limit was reported; the forecaster's own chance of this, stated with the estimate: 70%; the middle value sits exactly at the limit.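

In this assay compound 4 gives > 100000 nM, which is a limit of the assay, so its steps from compound 1, compound 2 and compound 3 cannot be read: the limit of > 100000 nM in this assay, at which 4 of the 4 values shown sit. The compounds shown leave open whether changing this group on the shared core alters the read-out at all.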